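The source may report more compounds than this note shows. Statements on the series, on what has been measured and on what is new or still open speak of the compounds shown alone.

Compound 3 `CCCn1c(-c2ccc(OCc3c(-c4c(Cl)cccc4Cl)noc3C(C)C)cc2)nc2ccc(C(=O)O)cc21` carries the highest number of the three measured in an assay on isolated protein for agonist activity at Bile acid receptor (Homo sapiens), read by TR-FRET (on this read-out higher numbers stand for an effect only at larger amounts of compound and lower numbers for an effect already at smaller amounts), where compound 3 gives 96.4 nM. Compound 1 `CCC(CC)n1c(-c2ccc(OCc3c(-c4c(Cl)cccc4Cl)noc3C(C)C)cc2)nc2ccc(C(=O)O)cc21` gives 26.5 nM and compound 2 `CCn1c(-c2ccc(OCc3c(-c4c(Cl)cccc4Cl)noc3C(C)C)cc2)nc2ccc(C(=O)O)cc21` gives 19.3 nM. Compound 4 `CC(C)c1onc(-c2c(Cl)cccc2Cl)c1COc1ccc(-c2nc3ccc(C(=O)O)cc3n2-c2ccc(F)cc2)cc1` differs from compound 3 by 4-fluorophenyl in place of propyl on an aromatic nitrogen. The measured steps all change chains on that same nitrogen: a 3.6-fold higher number from compound 1 to compound 3 (0.56 log units; beyond the scatter), a 5.0-fold higher number from compound 2 to compound 3 (0.70 log units; beyond the scatter) and a 1.4-fold lower number from compound 1 to compound 2 (0.14 log units; within the scatter). They show that the group on this nitrogen shifts the number modestly, but none of them brings in an aromatic ring, so the direction for compound 4 is uncertain. The step is expected to be a modest lowering toward the other measured values, a 2.4-fold lower number from compound 3 to compound 4 (0.38 log units; beyond the scatter). The estimate for compound 4 is 40 nM, with a range from 10 nM to 200 nM.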

Compound 4, half-maximal effective concentration: 15.1 nM
For compound 4 the middle estimate is 2.6-fold (0.42 log units) above the measured one, within the range that was stated.
By their numbers in this assay, from the lowest: compounds 4, 2 and 1 (each within the scatter of the next); then compound 3.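

Unlike the chains, an aromatic ring now sits on this nitrogen, and in this assay 4-fluorophenyl gives a 6.4-fold lower number from compound 3 to compound 4 (0.81 log units; beyond the scatter). Against the other two chains it shows no real change, with a 1.3-fold lower number from compound 2 to compound 4 (0.11 log units; within the scatter) and a 1.8-fold lower number from compound 1 to compound 4 (0.24 log units; within the scatter), so among these four groups only propyl stands apart. No measurement shown bears on the reason for this result. Going by these compounds, it remains open whether the fluorine matters, and how a plain phenyl, a benzyl or a phenyl ring carrying an amine would read on this nitrogen.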